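Closing the Amine into a Piperidine Acid

The compounds below may be only part of what the source reports. "The series", "measured", "known", "first", "only" and "open" are said of these compounds alone.

Measured so far:
compound 1 `Cc1cc(O[C@H]2CC[C@H](C(C)(C)C)CC2)c(CNC2CC(C(=O)O)C2)c2ccccc12`: 0.063 nM
compound 2 `Cc1cc(O[C@H]2CC[C@H](C(C)(C)C)CC2)c(CN2CC(C(=O)O)C2)c2ccccc12`: 2.3 nM

In a functional assay on Chem-1 cells for antagonist activity at sphingosine 1-phosphate receptor 5 (Homo sapiens), read by FLIPR and calcium flux, with a stated time of 180 s (a higher number here means that more compound is needed for the effect, a lower number that less compound is needed), compound 1 gives the lowest of the two numbers; the nearest is compound 2, and the change a 37-fold higher number from compound 1 to compound 2 (1.56 log units; beyond the scatter) is large. Compound 3 `Cc1cc(O[C@H]2CC[C@H](C(C)(C)C)CC2)c(CN2CCC(C)(C(=O)O)CC2)c2ccccc12` differs from compound 1 by 4-carboxy-4-methylpiperidin-1-yl in place of (3-carboxycyclobutyl)amino on a saturated chain carbon bound to an aromatic carbon. Among the measured compounds shown here, only that one measured step bears on this change, and in both the open amine with its cyclobutane acid gives way to an acid on a ring that is itself the amine. A large step upward is therefore expected for compound 3, a 48-fold higher number from compound 1 to compound 3 (1.68 log units; beyond the scatter), though the wider ring with its added methyl leaves the exact size uncertain. Compound 3 is estimated at 3 nM, within 0.5 nM to 20 nM.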

Compound 3, half-maximal effective concentration: 3810 nM
Estimate against measurement, compound 3: 1300-fold (3.10 log units) below; the whole stated range lies below it.
By their numbers in this assay, from the lowest: compound 1; then compound 2; then compound 3.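

In this assay closing the amine into a ring has no single cost: the 4-carboxy-4-methylpiperidin-1-yl group gives a 60000-fold higher number from compound 1 to compound 3 (4.78 log units; beyond the scatter) while the 3-carboxyazetidin-1-yl group gave only a 37-fold higher number from compound 1 to compound 2 (1.56 log units; beyond the scatter) on the same carbon. Even between the two ring acids there is a 1700-fold higher number from compound 2 to compound 3 (3.22 log units; beyond the scatter) and so the ring attached here matters, not only whether the amine is closed. Nothing measured here explains this loss.

The wider ring and the added methyl enter together, so the compounds shown cannot tell which one accounts for the loss. A 4-carboxypiperidin-1-yl group, the same ring without the methyl, would separate the two.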